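Shortening the sulfur-linked chain on a shared core

The source may report more compounds than this note shows. Statements on the series, on what has been measured and on what is new or still open speak of the compounds shown alone.

Measured so far in a functional assay on PC-9 cells (Homo sapiens) for inhibition, read by MTT assay, with a stated time of 72 h; on this read-out higher numbers stand for weaker inhibition and lower numbers for stronger inhibition:
Compound 1, `Cc1cc(Nc2cc(-c3ccccc3)[nH]n2)n2nc(SCCCc3ccccc3)nc2n1`: compound 1 gives 5030 nM.
Compound 2, `Cc1cc(Nc2cc(-c3ccccc3)[nH]n2)n2ncnc2n1`: compound 2 gives only a limit of the assay, > 50000 nM.
Compound 3, `Cc1cc(Nc2cc(-c3ccccc3)[nH]n2)n2nc(SCc3cccc4ccccc34)nc2n1`: compound 3 gives 3950 nM.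

Among the numbers shown, compound 1 has the highest; its nearest neighbour is compound 3, and that gap, a 1.3-fold lower number from compound 1 to compound 3 (0.10 log units; within the scatter), lies within the scatter, so the two cannot be ordered. Compound 2 sits at a limit, (the limit of > 50000 nM in this assay, at which 1 of the 3 values shown sits).

Compound 4, `C=CCSc1nc2nc(C)cc(Nc3cc(-c4ccccc4)[nH]n3)n2n1`, differs from compound 1 by vinyl in place of phenethyl on a saturated chain carbon bound to a sulfur. Going by the values given here, two measured steps bear on this. Stripping the whole group down to hydrogen gave an at least 9.9-fold higher number from compound 1 to compound 2 (0.99 log units; beyond the scatter), a clear loss of inhibition. Exchanging one large aromatic group for another gave a 1.3-fold lower number from compound 1 to compound 3 (0.10 log units; within the scatter), no change beyond the scatter. The change to compound 4 keeps the sulfur but removes most of the chain, so an expected step of a 3.0-fold higher number from compound 1 to compound 4 (0.47 log units; beyond the scatter), toward weaker inhibition but short of the loss seen for compound 2, seems reasonable. Compound 4 is therefore expected to give about 15000 nM in this assay, within a range of 5000 nM to 50000 nM.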

Compound 4, half-maximal inhibitory concentration: > 50000 nM
Compound 4 ended at the assay's limit; the forecaster's own chance of this, stated with the estimate: 20%; middle value at least 3.3-fold (0.52 log units) away from the limit.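

In this assay, keeping the sulfur is not enough: replacing (3-phenylpropyl)sulfanyl with allylsulfanyl gives an at least 9.9-fold higher number from compound 1 to compound 4 (0.99 log units; beyond the scatter), and replacing the naphthalen-1-yl group gives an at least 12-fold higher number from compound 3 to compound 4 (1.10 log units; beyond the scatter). Among the compounds shown, a readable number appears only where the sulfur-linked group carries an aromatic ring, as in compound 1 and compound 3, and no compound shown goes against this. Compound 2 and compound 4 both sit at a limit rather than at a number, so the step between them cannot be read: the limit of > 50000 nM in this assay, at which 2 of the 4 values shown sit.

Allyl differs from 3-phenylpropyl in both size and the presence of a ring, so the compounds shown do not separate these two changes. A hexyl chain on the sulfur, which has no ring, or a benzyl group, which keeps the ring on a shorter link, would pull them apart.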